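From (4-Chlorobenzyl)sulfanyl Back to Phenoxy: An Expected Drop

The source may hold more compounds than are shown below. What is called first, only, known or untested is meant among the compounds shown, and "the series" means these compounds.

Of the compounds shown here, three have so far been tested in an assay on isolated protein for inhibition of melanin-concentrating hormone receptor 1 (Homo sapiens), tested at 1 uM; on this read-out lower numbers stand for less inhibition and higher numbers for more inhibition at the one concentration tested (going by the name of the read-out). Compound 1 `COc1cccc(OCC(=O)Nc2ccc3nc(N4CCN(C)CC4)cc(C)c3c2)c1` gives 9%, compound 2 `Cc1cc(N2CCN(C)CC2)nc2ccc(NC(=O)CSCc3ccc(Cl)cc3)cc12` gives 38%, and compound 3 `Cc1cc(N(C)Cc2ccccc2)nc2ccc(NC(=O)COc3ccc(C(F)(F)F)cc3)cc12` gives 40%. Compound 2 thus stands second highest of the three: its nearest neighbour is compound 3, whose number lies within the scatter of its own, while compound 1 sits well below it, the one gap that is beyond the scatter. Among the compounds with values here, that gap is the single measured step of this kind, a number 29 percentage points higher from compound 1 to compound 2 (beyond the scatter), and it is also the only step that bears on the compound still to come.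

Compound 4 `Cc1cc(N2CCN(C)CC2)nc2ccc(NC(=O)COc3ccccc3)cc12` differs from compound 2 in one place: phenoxy in place of (4-chlorobenzyl)sulfanyl on a saturated chain carbon bound to a carbonyl carbon. This is close to a reversal of the measured step, because the group that leaves in a number 29 percentage points higher from compound 1 to compound 2 (beyond the scatter) is the one that now enters, and the group entering here is a phenoxy like the one that left, only without the methoxy. A downward step of roughly similar size is therefore expected, a number 24 percentage points lower from compound 2 to compound 4 (beyond the scatter). Compound 4 is accordingly estimated at 14% in this assay, most likely between 0% and 32%.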

Compound 4, a percentage reported as inhibition, at one concentration (the size of the read-out at that concentration, not a potency): 2%
Estimate against measurement, compound 4: 12 percentage points above; low and high end bracket the measured number.
By their numbers in this assay, from the lowest: compounds 4 and 1 (each within the scatter of the next); then compounds 2 and 3 (each within the scatter of the next).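

In this assay, the change on a saturated chain carbon bound to a carbonyl carbon now gives a number 36 percentage points lower from compound 2 to compound 4 (beyond the scatter) as a second, large drop, so the higher number of compound 2 no longer rests on a single comparison with a 3-methoxyphenoxy partner. The methoxy group adds little to this picture: hydrogen in place of methoxy on an aromatic carbon gives a number 7 percentage points lower from compound 1 to compound 4 (within the scatter) and so leaves 3-methoxyphenoxy and phenoxy unseparated in this assay, which ties the gain to (4-chlorobenzyl)sulfanyl rather than to the loss of that one methoxy group. No measurement offered here explains why this group gives the higher number.

Still open, from the compounds shown here alone, is which part of (4-chlorobenzyl)sulfanyl goes with the higher number, given that the sulfur and the chlorine both leave in this one change, along with the carbon that links the sulfur to the ring. A (4-chlorobenzyl)oxy group at the same place would isolate the sulfur, while a plain benzylsulfanyl group would isolate the chlorine, and a 4-chlorophenoxy group would show whether chlorine alone can lift a phenoxy compound.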